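The source may hold more compounds than are shown below. What is called first, only, known or untested is meant among the compounds shown, and "the series" means these compounds.

Working notes on the series in a functional assay on 786-0 cells (Homo sapiens) for inhibition, read by sulforhodamine B assay, with a stated time of 48 h, tested at 10 uM; a higher number here means more inhibition at the concentration tested (going by the name of the read-out), a lower number less inhibition.

Two compounds carry the shared core with an aryl group on it. Compound 1 `c1ccc(-c2cn3ccnc3c(-c3ccc4ncn(C5CCCCC5)c4c3)n2)cc1` bears the unsubstituted phenyl and in this assay compound 1 gives 36.8%. Among the compounds with values here, compound 2 `COc1ccc(-c2cn3ccnc3c(-c3ccc4ncn(C5CCCCC5)c4c3)n2)cc1` bears the 4-methoxyphenyl; in this assay compound 2 gives 83.2%, the higher of the two numbers measured so far. Within the data shown here, the one step recorded, a number 46.4 percentage points higher from compound 1 to compound 2 (beyond the scatter), comes from methoxy in place of hydrogen on an aromatic carbon.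

Compound 3 `O=Cc1ccc(-c2cn3ccnc3c(-c3ccc4ncn(C5CCCCC5)c4c3)n2)cc1` is the next case. It differs from compound 2 by formyl in place of methoxy on an aromatic carbon, placed on an aromatic carbon of a six-membered aromatic ring of carbon only, para to a large group. Among the measured compounds shown here, no measured step covers a swap of one substituent for another at this place; the only step on record concerns adding methoxy to hydrogen and it was large. On these data alone, whether formyl keeps what methoxy gave is unknown, so the estimate for compound 3 in this assay is 60%, range 30% to 88%, which means an expected step of a number 23.2 percentage points lower from compound 2 to compound 3 (beyond the scatter) with wide uncertainty.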

Compound 3, a percentage reported as inhibition, at one concentration (the size of the read-out at that concentration, not a potency): 46.7%
Estimate against measurement, compound 3: 13.3 percentage points above; the measured number falls inside the stated range.
By their numbers in this assay, from the lowest: compounds 1 and 3 (each within the scatter of the next); then compound 2.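

In this assay, the replacement at this place, on an aromatic carbon para to a large group, shows that the high number of compound 2 does not carry over to every substituent there: a number 36.5 percentage points lower from compound 2 to compound 3 (beyond the scatter), although methoxy and formyl match in their counts of heavy atoms and hydrogen-bond acceptors. Against the unsubstituted phenyl, a number 9.9 percentage points higher from compound 1 to compound 3 (within the scatter), so formyl leaves this position indistinguishable from hydrogen and, among these three compounds, only methoxy stands clear of the others. Nothing available on these compounds bears on why methoxy and formyl part so sharply at this position.

The compounds shown leave open whether the number of compound 2 depends on an oxygen attached directly to the ring, which a hydroxyl or a longer chain such as ethoxy would test at the same carbon. They also leave open whether an amine or a carboxylic acid at this place would fall with methoxy or with formyl, and whether methoxy would give a step of similar size on another carbon of this ring.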